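A few compounds are considered here, and "the series" means these few. Any claim that something is new, unique, unknown or untested is made for them only; others in the source may bear on it.

Compound 3 `NS(=O)(=O)c1cc(-c2nnc(Cn3cc(-c4ccccc4)nn3)o2)c(Cl)cc1SCc1ccccc1` sits at the low end of the three numbers measured in a functional assay on HeLa cells (Homo sapiens) for cytotoxicity, read by MTT assay, with a stated time of 72 h; a lower number here means a stronger inhibitor, a higher number a weaker inhibitor: compound 3 gives 7000 nM, while compound 2 `CC(C)(O)c1cn(Cc2nnc(-c3cc(S(N)(=O)=O)c(SCc4ccccc4)cc3Cl)o2)nn1` gives 68000 nM and compound 1 `CCOC(=O)c1cn(Cc2nnc(-c3cc(S(N)(=O)=O)c(SCc4ccccc4)cc3Cl)o2)nn1` gives 122000 nM. The steps among these three all change the group on the triazole: a 1.8-fold lower number from compound 1 to compound 2 (0.25 log units; within the scatter), a 17-fold lower number from compound 1 to compound 3 (1.24 log units; beyond the scatter), and a 9.7-fold lower number from compound 2 to compound 3 (0.99 log units; beyond the scatter). Compound 4 `NS(=O)(=O)c1cc(-c2nnc(CNC(=O)c3ccccc3)o2)c(Cl)cc1SCc1ccccc1` goes a different way, as benzamido in place of 4-phenyl-1H-1,2,3-triazol-1-yl on a saturated chain carbon bound to an aromatic carbon. Among the compounds with values here, none of the measured steps touches the triazole itself, so none bears directly on this change; they show only that a phenyl on that ring brought the number well down, and compound 4 keeps a phenyl but loses the ring that carried it. The expectation is therefore a move back upward, of a size between the steps already seen, with wide uncertainty. Compound 4 is expected to give an estimated 30000 nM in this assay, with a range from 8000 nM to 120000 nM, which would mean an expected step of a 4.3-fold higher number from compound 3 to compound 4 (0.63 log units; beyond the scatter).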

Compound 4, half-maximal inhibitory concentration: 105000 nM
Estimate against measurement, compound 4: 3.5-fold (0.54 log units) below; the range from low to high includes it.
By their numbers in this assay, from the lowest: compound 3; then compounds 2, 4 and 1 (each within the scatter of the next).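

In this assay, the change to benzamido costs compound 3 its low number (a 15-fold higher number from compound 3 to compound 4 (1.18 log units; beyond the scatter)), so on this saturated chain carbon a phenyl alone does not keep that number; among the compounds shown, it goes with the 4-phenyl-1H-1,2,3-triazol-1-yl group. The benzamido group also reads level with the two other substituted triazoles, as both steps lie within the scatter (a 1.5-fold higher number from compound 2 to compound 4 (0.19 log units; within the scatter); a 1.2-fold lower number from compound 1 to compound 4 (0.07 log units; within the scatter)), so compound 3 alone stands apart at this position. Nothing available explains why the triazole carrying phenyl differs from benzamido.

From the compounds shown here alone, it remains open whether the phenyl of compound 4 contributes anything, which an acetamido group or a free amine at this place could test. Going by these compounds, it is also open whether a longer chain between the amide and the phenyl, as in phenylacetamido, would change the number.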